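Amide Nitrogen Substitution and Inhibition of Paw Edema

This account rests on a few compounds, and the source may have more. Where it says the series, first, only, none or still open, it means among the compounds named here.

Measured compounds:
compound 1, `CC(=O)c1ccc(NC(=O)c2nc(-c3ccccc3)n(-c3ccc(S(N)(=O)=O)cc3)n2)cc1`, 42%
compound 2, `NC(=O)c1nc(-c2ccccc2)n(-c2ccc(S(N)(=O)=O)cc2)n1`, 42%
compound 3, `NS(=O)(=O)c1ccc(-n2nc(C(=O)NC3CCCCC3)nc2-c2ccccc2)cc1`, not yet measured

The measurement here is a functional assay on the whole organism for inhibition, with Rattus norvegicus as the target, read by paw edema, with stated times of 30 min and 5 h, at a dose of 0.28 mmol/kg by the oral route; on this read-out higher numbers stand for more inhibition at the one dose given (going by the name of the read-out) and lower numbers for less inhibition. Compound 1 and compound 2 share a core and differ only on the amide-type nitrogen, where compound 1 carries a 4-acetylphenyl group and compound 2 a hydrogen. The step between them reads no change at the digits printed from compound 1 to compound 2 (within the scatter). Compound 2 therefore stands level with compound 1, and the two values give no order between them.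

Compound 3 is built from compound 2 by cyclohexyl in place of hydrogen on an amide-type nitrogen. For the measured compounds named here, the only measured step that bears on this is the one from compound 1 to compound 2, which concerns the same amide-type nitrogen and showed no movement beyond the scatter when a large aryl group gave way to hydrogen. On that basis no step beyond the scatter is expected when a cyclohexyl group takes the place of the hydrogen in compound 3, so that no change at the digits printed from compound 2 to compound 3 (within the scatter) is the expected step. Compound 3 is accordingly estimated at 42% in this assay, with a range from 28% to 56%.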

Compound 3, a percentage reported as inhibition, in the whole organism at one dose (the size of the read-out at that dose, not a potency): 42%
Beside the measured number, compound 3's estimate shows no gap at the digits printed; the measured number falls inside the stated range.
By their numbers in this assay, from the lowest: compounds 1, 2 and 3 (each within the scatter of the next).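

In this assay, cyclohexyl in place of hydrogen on the amide-type nitrogen gives no change at the digits printed from compound 2 to compound 3 (within the scatter), so a six-membered non-aromatic ring of carbon only now joins hydrogen and 4-acetylphenyl among the groups seen at this position. The direct exchange of 4-acetylphenyl for cyclohexyl gives no change at the digits printed from compound 1 to compound 3 (within the scatter), which adds a comparison between two ring-bearing groups to the earlier one between 4-acetylphenyl and hydrogen. Across these three compounds, the read-out at this one dose does not separate any of the groups on this nitrogen.

The compounds shown leave open whether a group carrying an amine or a carboxylic acid, or a longer alkyl chain, on this nitrogen would also leave the read-out unmoved. Because the shared core stays the same in all three, they also leave open how changes elsewhere on it would read, and whether a second group on the amide-type nitrogen would matter. No measurement among those shown offers an explanation for this result.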